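The compounds below may be only part of what the source reports. "The series", "measured", "known", "first", "only" and "open" are said of these compounds alone.

Measured compounds in the series:

compound 1, `NC(=O)/C=C/c1ccncc1-c1ccc2ccccc2c1`, in a functional assay on HCT-116 cells (Homo sapiens) for inhibition, read by MTT assay, with a stated time of 72 h (a lower number here means a stronger inhibitor of growth, a higher number a weaker inhibitor of growth), gives 12100 nM
compound 2, `CNC(=O)COc1ccncc1-c1ccc2ccccc2c1`, in this assay gives "not determined" (no result reported)

Compound 2 stands nowhere on the numbers: its result in this assay is recorded as "not determined" (no result reported), so there is no single number for it and nothing to place against compound 1. The only measured point in the series is compound 1, and in this assay compound 1 gives 12100 nM, which sets the series in the weak range of growth inhibition.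

Compound 3, `NNC(=O)CCc1ccncc1-c1ccc2ccccc2c1`, is the next step from compound 2. The change is 2-(aminocarbamoyl)ethyl in place of (methylcarbamoyl)methoxy on an aromatic carbon

Among the compounds with values here, no step between two measured compounds exists, so the size of this change in this assay cannot be read from the data, and with compound 2 lacking a number no direction can be stated either; the shift may well stay within the scatter. The expectation for compound 3 therefore rests on compound 1 alone, whose value 12100 nM marks the level the shared core has shown so far. Compound 3 is expected to give about 15000 nM in this assay, with a likely range from 4000 nM to 60000 nM.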

Compound 3, concentration for 50% growth inhibition: > 30000 nM
Compound 3 gave a limit, no number; the forecaster's own chance of this, stated with the estimate: 15%; at least 2.0-fold (0.30 log units) between middle value and limit.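

In this assay compound 3 gives a limit and not a number: the limit of > 30000 nM in this assay, at which 1 of the 3 values shown sits.

Within the data shown here, on an aromatic carbon ortho to a large group and opposite the ring nitrogen, 2-(aminocarbamoyl)ethyl in place of 2-carbamoylethenyl gives an at least 2.4-fold higher number from compound 1 to compound 3 (0.39 log units; beyond the scatter), the first readable step and one that goes towards weaker growth inhibition, so the group at this position does change the read-out in this assay. Steps involving compound 2 cannot be read, as it has no number, and the step above gives only a lower bound on the size of the loss, not its full size.

The step changes the chain in two ways at once, the ethenyl link becoming ethyl and the carbamoyl end becoming aminocarbamoyl, and the compounds shown do not tell which of the two accounts for the loss; 2-carbamoylethyl would separate them. As far as these compounds go, whether a carboxylic acid or an amine at the end of the chain, or a longer chain, would hold the level of compound 1 also stays open.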